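Fluoro to Chloro: A Small Expected Step

A few compounds are considered here, and "the series" means these few. Any claim that something is new, unique, unknown or untested is made for them only; others in the source may bear on it.

Of the compounds shown here, two have so far been read in an ADME assay on HUVEC cells (Homo sapiens) for cytotoxicity, read by MTT assay, with a stated time of 24 h; on this read-out lower numbers stand for higher toxicity in this test and higher numbers for lower toxicity in this test. Compound 1 (`Brc1cccc(/C=C/c2nnc(-c3ccc4c(c3)OCCO4)o2)c1`) gives 322000 nM. Compound 2 (`Fc1ccccc1/C=C/c1nnc(-c2ccc3c(c2)OCCO3)o1`) gives 402000 nM. Within the data shown here, compound 2 therefore stands level with its only measured neighbour, as the one measured step shows: a 1.2-fold higher number from compound 1 to compound 2 (0.10 log units; within the scatter).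

The next structure, compound 3 (`Clc1ccccc1/C=C/c1nnc(-c2ccc3c(c2)OCCO3)o1`), departs from compound 2 by a single exchange: chloro in place of fluoro on an aromatic carbon. In words, this is chloro in place of fluoro on an aromatic carbon, or 2-fluorophenyl to 2-chlorophenyl, ortho to a large group. Among the measured compounds shown here, no measured pair covers this exact exchange. For the measured compounds named here, the nearest evidence is the one step already seen, which also replaced one halogen-bearing group with another and stayed within the scatter: a 1.2-fold higher number from compound 1 to compound 2 (0.10 log units; within the scatter). Going by the values given here, with only this step to go on, no change beyond the scatter is expected in this assay, and no direction can be firmly assigned. The expected step is a 1.1-fold lower number from compound 2 to compound 3 (0.06 log units; within the scatter). Compound 3 is estimated at 350000 nM, with an expected range from 180000 nM to 680000 nM.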

Compound 3, half-maximal cytotoxic concentration: 368000 nM
For compound 3 the middle estimate is 1.1-fold (0.02 log units) below the measured one; the measured number falls inside the stated range.
By their numbers in this assay, from the lowest: compounds 1, 3 and 2 (each within the scatter of the next).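

Chloro in place of fluoro on an aromatic carbon, ortho to a large group, gives the first direct reading of an exchange at this position in this assay (a 1.1-fold lower number from compound 2 to compound 3 (0.04 log units; within the scatter)), and it does not tell these two halogens apart. The 2-chlorophenyl group is likewise not told apart from the 3-bromophenyl group of compound 1 (a 1.1-fold higher number from compound 1 to compound 3 (0.06 log units; within the scatter)), so each of the three pairs now read lies within the scatter, and the earlier level reading for the 2-fluorophenyl and 3-bromophenyl groups no longer stands alone. No measured information is available that would explain this result.

As far as these compounds go, all three compounds carry a single halogen on the phenyl ring, so it remains open whether a group of another kind at this position, such as an amine, a carboxylic acid or a methoxy group, would move the number beyond the scatter in this assay. From the compounds shown here alone, it also remains open whether an unsubstituted phenyl group or a change elsewhere in the shared core would leave the number as level as these halogen exchanges do.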